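The source may hold more compounds than are shown below. What is called first, only, known or untested is meant among the compounds shown, and "the series" means these compounds.

Measured so far in a functional assay on the whole organism (strain Charles Foster albino) for inhibition, with Rattus norvegicus as the target, read by paw edema, with stated times of 30 min and 3 h, at a dose of 50 mg/kg by the oral route; a lower number here means less inhibition, a higher number more inhibition at the dose given (going by the name of the read-out):
compound 1, `COc1ccc(OC)c(C2CC(c3cccnc3)=NN2c2ccccc2)c1`, 24%
compound 2, `COc1ccc(OC)c(C2CC(c3ccncc3)=NN2c2ccccc2)c1`, 18%
compound 3, `CN(C)c1ccc(C2CC(c3cccnc3)=NN2c2ccccc2)cc1`, 34%

Compound 1 and compound 2 share a core and differ only by pyridin-4-yl in place of pyridin-3-yl on a carbon with a double bond to nitrogen; the step is a number 6 percentage points lower from compound 1 to compound 2 (within the scatter). Compound 3 carries a different core, and how its core differs from that of compound 1 is not broken down here. Compound 3 gives the highest of the three numbers, within the scatter of compound 1 and beyond it only against compound 2. Compound 4, `CN(C)c1ccc(C2CC(c3ccncc3)=NN2c2ccccc2)cc1`, has not yet been measured in this assay. It differs from compound 3 by pyridin-4-yl in place of pyridin-3-yl on a carbon with a double bond to nitrogen, the same kind of change as that between compound 1 and compound 2; the surroundings read alike except that one ring atom is described as bearing a group of 9 heavy atoms in one case and a large group in the other. Because the earlier step was a number 6 percentage points lower from compound 1 to compound 2 (within the scatter), the step from compound 3 to compound 4 is expected to be small as well, a number 6 percentage points lower from compound 3 to compound 4 (within the scatter). Compound 4 is therefore estimated at 28%, most likely between 16% and 40%.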

Compound 4, a percentage reported as inhibition, in the whole organism at one dose (the size of the read-out at that dose, not a potency): 32%
Compound 4: middle estimate off by 4 percentage points, on the low side; low and high end bracket the measured number.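

Set on the core of compound 3, pyridin-4-yl in place of pyridin-3-yl on a carbon with a double bond to nitrogen gives, in this assay, a number 2 percentage points lower from compound 3 to compound 4 (within the scatter). Placed beside the earlier step, the same change reads alike on the two cores: the same change on two cores in this assay, a number 6 percentage points lower (within the scatter) from compound 1 to compound 2 and a number 2 percentage points lower (within the scatter) from compound 3 to compound 4, 4 percentage points apart, within the scatter of two such steps. This shows that on these two cores the exchange of one pyridine attachment for the other gave no step beyond the scatter, but it does not show that the same would hold on any further core, nor can it resolve a small real step hidden within the scatter, and a reading at one dose says nothing about potency.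

The compounds shown leave open how a pyridin-2-yl group or a carboxylic acid would read on that same carbon. They also leave open whether a longer chain at the ring atom that bears a phenyl group would alter the picture.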